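The source may hold more compounds than are shown below. What is called first, only, known or untested is meant among the compounds shown, and "the series" means these compounds.

Going by the values given here, in a functional assay on DU-145 cells (Homo sapiens) for inhibition, read by trypan blue exclusion, with a stated time of 96 h (on this read-out lower numbers stand for stronger inhibition of growth and higher numbers for weaker inhibition of growth), compound 2 `O=C(/C(=C\c1ccc(O)cc1)SCc1ccc(Cl)cc1)c1ccc(Br)cc1` gives 10000 nM, the lower of the two numbers measured so far. Compound 1 `CN(C)c1ccc(/C=C(/SCc2ccc(F)cc2)C(=O)c2ccc(Br)cc2)cc1` gives 50000 nM, a higher number, and the gap between compound 2 and compound 1 lies beyond the scatter. Compound 3 `O=C(O)c1cc(/C=C(\C(=O)c2c(F)c(F)c(F)c(F)c2F)S(=O)(=O)c2ccc(Br)cc2)ccc1O` sits at the limit of > 100000 nM in this assay, at which 1 of the 3 values shown sits, so for compound 3 the read-out of > 100000 nM is a limit of this assay rather than a number. Compound 4 `O=C(/C(=C\c1ccc(Cl)cc1)SCc1ccc(Cl)cc1)c1ccc(Br)cc1` is compound 2 with one change: chloro in place of hydroxy on an aromatic carbon. Among the compounds with values here, no measured pair shows this same change, so the expectation rests on the change alone, and a step no larger than the usual scatter is expected in either direction. Compound 4 is expected to give 10000 nM, between 3000 nM and 40000 nM. The expected step from compound 2 to compound 4 is no change at the digits printed from compound 2 to compound 4 (within the scatter).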

Compound 4, concentration for 50% growth inhibition: 10000 nM
The estimate for compound 4 equals the measured number at the digits printed; the measured number falls inside the stated range.
By their numbers in this assay, from the lowest: compounds 2 and 4 (each within the scatter of the next); then compound 1. At a limit, above all of these: compound 3.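

Replacing hydroxy with chloro in the 4-hydroxyphenyl to 4-chlorophenyl change gives no change at the digits printed from compound 2 to compound 4 (within the scatter). Going by these compounds alone, this is the first direct comparison at this position, and it shows that here the hydroxy group's hydrogen-bond donor and acceptor can leave without moving the number beyond the scatter. The data shown give no explanation for this result.

The compounds shown leave open whether other groups at this position, such as methoxy or nitrile, would also leave the number in place. As far as these compounds go, whether the same swap behaves alike on another core also remains open.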